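The compounds below may be only part of what the source reports. "The series", "measured", "known", "first", "only" and "open" are said of these compounds alone.

Of the compounds shown here, three of one shared core have been measured in a functional assay on CHO cells for agonist activity at Alpha-1A adrenergic receptor (Homo sapiens), read by FLIPR and calcium flux; a lower number here means a smaller maximal response, a higher number a larger maximal response. Compound 3 `Clc1cccc(C2CCc3nc[nH]c3C2)c1` gives 71%, compound 1 `COc1cccc(C2CCc3nc[nH]c3C2)c1` gives 60%, and compound 2 `Clc1ccccc1C1CCc2nc[nH]c2C1` gives 60%, level with compound 1. From compound 3 to compound 1 the change is methoxy in place of chloro on an aromatic carbon, and a number 11 percentage points lower from compound 3 to compound 1 (beyond the scatter). How compound 2 differs from compound 3 is not broken down here. Compound 4 `COc1ccccc1C1CCc2nc[nH]c2C1` awaits measurement; from compound 2 to compound 4 the change is methoxy in place of chloro on an aromatic carbon, the same kind of change, though here ortho rather than meta to a group of 9 heavy atoms. Resting on the single earlier step of a number 11 percentage points lower from compound 3 to compound 1 (beyond the scatter), a step of a number 8 percentage points lower from compound 2 to compound 4 (within the scatter) is expected, so that compound 4 is estimated to give 52%, between 38% and 66%.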

Compound 4, largest response reached (Emax), in percent of the reference or control that the assay uses: 95%
Compound 4: middle estimate off by 43 percentage points, on the low side, outside the stated range (above it).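

Methoxy in place of chloro on an aromatic carbon, here ortho to a group of 9 heavy atoms, gives a number 35 percentage points higher from compound 2 to compound 4 (beyond the scatter) in this assay. Set beside the earlier step, the change did not carry over from one core to the other, either in direction or in size: the same change on two cores in this assay, a number 11 percentage points lower (beyond the scatter) from compound 3 to compound 1 and a number 35 percentage points higher (beyond the scatter) from compound 2 to compound 4, 46 percentage points apart, beyond the scatter of two such steps

This comparison rests on a single pair of steps; it shows that the result of this change cannot be transferred between these two cores, but it does not show what sets them apart or how the change would behave elsewhere in the series.

The compounds shown carry only chloro or methoxy on the aromatic ring. From the compounds shown here alone, how a hydroxyl, an amine or a longer alkoxy chain would behave there remains open.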